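Working notes: acetyl versus methyl-tosyl on the benzylic amine

A few compounds are considered here, and "the series" means these few. Any claim that something is new, unique, unknown or untested is made for them only; others in the source may bear on it.

Measured in a functional assay (aorta) for antagonist activity, with Oryctolagus cuniculus as the target; a higher number here means a weaker inhibitor, a lower number a stronger inhibitor:
- compound 1, `CCCCc1ccc(CN)c(=O)n1Cc1ccc(-c2ccccc2-c2nn[nH]n2)cc1`, gives 20 nM
- compound 2, `CCCCc1ccc(CNC(C)=O)c(=O)n1Cc1ccc(-c2ccccc2-c2nn[nH]n2)cc1`, gives 3 nM
- compound 3, `CCCCc1ccc(CN(Cc2ccccc2)S(=O)(=O)c2ccc(C)cc2)c(=O)n1Cc1ccc(-c2ccccc2-c2nn[nH]n2)cc1`, gives 60 nM

Compound 2 holds the lowest number of the three in this assay; compound 1 stands nearest to it and compound 3 furthest, both gaps beyond the scatter. Going by the values given here, the only step worked out within the set is a 6.7-fold lower number from compound 1 to compound 2 (0.82 log units; beyond the scatter), the gain from placing the acetyl on the amine nitrogen.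

Compound 4, `CCCCc1ccc(CN(C)S(=O)(=O)c2ccc(C)cc2)c(=O)n1Cc1ccc(-c2ccccc2-c2nn[nH]n2)cc1`, differs from compound 2 by methyl((4-methylphenyl)sulfonyl)amino in place of acetamido on a saturated chain carbon bound to an aromatic carbon. Among the compounds with values here, no step between compound 2 and compound 3 has been computed; their two values show only that compound 3, which carries a benzyl together with the same (4-methylphenyl)sulfonyl on that nitrogen, gives a higher number than compound 2. The step from compound 1 to compound 2 bears on the present change only in that it concerns the same nitrogen; it says nothing about a sulfonyl group.

Because compound 3 gives 60 nM in this assay and compound 2 gives 3 nM, compound 4 is expected to fall between them, estimated as a 6.7-fold higher number from compound 2 to compound 4 (0.82 log units; beyond the scatter). The estimate for compound 4 in this assay is 20 nM, with a range of 6 nM to 70 nM.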

Compound 4, half-maximal inhibitory concentration: 8 nM
Compound 4: middle estimate off by 2.5-fold (0.40 log units), on the high side; the measured number falls inside the stated range.
By their numbers in this assay, from the lowest: compound 2; then compound 4; then compound 1; then compound 3.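

In this assay, the nitrogen on the saturated chain carbon accepts a much larger group at a modest cost: acetamido gives way to methyl((4-methylphenyl)sulfonyl)amino with a 2.7-fold higher number from compound 2 to compound 4 (0.43 log units; beyond the scatter). The lower number relative to the free amine is also not confined to the acetyl group, since a 2.5-fold lower number from compound 1 to compound 4 (0.40 log units; beyond the scatter) runs in the same direction as the step from amino to acetamido, though it is smaller. Most of the higher number of compound 3 goes with the phenyl of its benzyl group rather than with the (4-methylphenyl)sulfonyl, which both compounds carry: a 7.5-fold lower number from compound 3 to compound 4 (0.88 log units; beyond the scatter) for hydrogen in place of that phenyl.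

On these data alone, the step from acetamido changes the acyl part and the substituent on the nitrogen together, so the shares of the methyl and of the (4-methylphenyl)sulfonyl remain open, and methanesulfonyl in place of (4-methylphenyl)sulfonyl, or hydrogen in place of the methyl on that nitrogen, would bear on that question. No supporting measurement accompanies these numbers to explain any of the steps.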